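Solubility notes on a pyridinone amide series

A few compounds are considered here, and "the series" means these few. Any claim that something is new, unique, unknown or untested is made for them only; others in the source may bear on it.

Measured so far in a physicochemical assay for solubility, read by HPLC, in simulated intestinal fluid, with a stated time of 16 h, tested at 125 ug/mL; a higher number here means a more soluble compound, a lower number a less soluble compound:
compound 1 `CNC(=O)c1cc(C(=O)NC2CCC2)cn(Cc2ccncc2)c1=O` gives 121 ug/mL
compound 2 `CNC(=O)c1cc(C(=O)NC2CCC2)cn(Cc2ccccc2)c1=O` gives 24 ug/mL
compound 3 `CNC(=O)c1cc(C(=O)NC2CC2)cn(Cc2cccc3cc[nH]c23)c1=O` gives 11 ug/mL

Compound 3 stands lowest of the three numbers in this assay; compound 2 sits nearest to it and compound 1 furthest, both gaps beyond the scatter.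

Compound 4 `CNC(=O)c1cc(C(=O)NC2CC2)cn(Cc2ccc(F)cc2)c1=O` is not yet measured. It differs from compound 3 as follows: 4-fluorophenyl in place of 1H-indol-7-yl on a saturated chain carbon bound to an aromatic nitrogen. Among the compounds with values here, no measured step covers this exact exchange. Within the data shown here, the only step changes the same group on the same saturated chain carbon bound to the aromatic nitrogen: a 5.0-fold lower number from compound 1 to compound 2 (0.70 log units; beyond the scatter), a modest drop. Compound 3 and compound 2 also differ in that group, and their two values show compound 2 somewhat higher. Compound 4 carries a six-membered aromatic ring of carbon only at that place, as compound 2 does, so a small rise from compound 3 toward the value of compound 2 is expected in this assay, a 2.3-fold higher number from compound 3 to compound 4 (0.36 log units; beyond the scatter), though the gap may not exceed the scatter. Compound 4 is estimated at 25 ug/mL, within 10 ug/mL to 60 ug/mL.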

Compound 4, solubility: 84 ug/mL
Compound 4: the middle estimate sits 3.4-fold (0.53 log units) below what was measured; measured number outside the range, above it.
By their numbers in this assay, from the lowest: compound 3; then compound 2; then compounds 4 and 1 (each within the scatter of the next).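

In this assay the group on a saturated chain carbon bound to an aromatic nitrogen can now be seen to move the number upward as well as downward: 4-fluorophenyl in place of 1H-indol-7-yl gives a clear rise (a 7.6-fold higher number from compound 3 to compound 4 (0.88 log units; beyond the scatter)). Set against the earlier exchange at this place (a 5.0-fold lower number from compound 1 to compound 2 (0.70 log units; beyond the scatter)), both steps lie beyond the scatter and run in opposite directions, so a six-membered aromatic ring of carbon only does not by itself mean a low number here. No measurement at hand bears on why the number rises.

This one exchange removes the five-membered aromatic ring and the hydrogen-bond donor and adds fluorine together, and the compounds shown do not separate these changes. Also open, on these data alone, is how an amine or a carboxylic acid on the phenyl ring would read at this place.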